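Cytotoxicity notes: piperidinyl in place of methylphenyl

A few compounds are considered here, and "the series" means these few. Any claim that something is new, unique, unknown or untested is made for them only; others in the source may bear on it.

Compound 2 `Cc1ccccc1COc1ccc2c(c1)[C@@H](O)CN(C)C2` in an ADME assay on Vero cells (Chlorocebus sabaeus) for cytotoxicity, read by sulforhodamine B assay, with a stated time of 72 h (on this read-out lower numbers stand for stronger inhibition and higher numbers for weaker inhibition), gives only a limit, > 100000 nM. Compound 1 `COc1ccc(COc2ccc3c(c2)[C@@H](O)CN(C)C3)cc1` likewise returns only a limit, > 50000 nM. Compound 3 `CCCCCCCCCCCCOc1ccc2c(c1)[C@@H](O)CN(C)C2` gives a number, 18300 nM. Compound 2 thus stands at the limit of > 100000 nM in this assay, at which 1 of the 3 values shown sits, the higher of the two limits shown, while compound 1 sits at the limit of > 50000 nM in this assay, at which 1 of the 3 values shown sits. Compound 4 `CN1Cc2ccc(OCC3CCNCC3)cc2[C@@H](O)C1` differs from compound 2 by piperidin-4-yl in place of 2-methylphenyl on a saturated chain carbon bound to an oxygen on an aromatic ring. For the measured compounds named here, no measured step of this kind is available in this assay. The step from compound 2 to compound 4 is expected to lie within the scatter, with no shift beyond it in either direction. Compound 4 is estimated at 150000 nM, range 40000 nM to 500000 nM, and most probably again a limit. The expected step is a step that the limit leaves unreadable from compound 2 to compound 4.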

Compound 4, half-maximal inhibitory concentration: > 100000 nM
Compound 4 gave a limit, no number; the forecaster's own chance of this, stated with the estimate: 75%; the middle value is on the limit's open side.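

For the compounds shown here, compound 2 and compound 4 both give only limits in this assay, and no step between them can be read. The compounds shown leave open whether piperidin-4-yl in place of 2-methylphenyl changes the read-out at all.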